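Changing the Sulfonyl-Side Ring of a Factor X Series

This account rests on a few compounds, and the source may have more. Where it says the series, first, only, none or still open, it means among the compounds named here.

Compound 1 `O=C1[C@@H](NS(=O)(=O)c2nc3cc(Cl)ccc3[nH]2)CCN1Cc1cc2c[nH]ccc-2n1` stands highest of the three compounds measured in an assay on isolated protein for inhibition of coagulation factor X (Oryctolagus cuniculus), tested at 1 uM (on this read-out higher numbers stand for more inhibition at the one concentration tested (going by the name of the read-out) and lower numbers for less inhibition), where compound 1 gives 31%. Compound 3 `O=C1[C@@H](NS(=O)(=O)c2nc3cc(Cl)ccc3[nH]2)CCN1CCNc1ccncc1` gives 29%, and compound 2 `O=C1[C@@H](NS(=O)(=O)c2nc3cc(Cl)ccc3[nH]2)CCN1Cc1cc2[nH]cccc-2n1` gives 14%. The steps of a number 17 percentage points lower from compound 1 to compound 2 (beyond the scatter) and a number 15 percentage points higher from compound 2 to compound 3 (beyond the scatter) both alter the group on a saturated chain carbon bound to an amide-type nitrogen in a ring, while the step of a number 2 percentage points lower from compound 1 to compound 3 (within the scatter) lies within the scatter. Compound 4 `O=C1[C@@H](NS(=O)(=O)c2cc3nc(Cl)ccc3s2)CCN1Cc1cc2c[nH]ccc-2n1` differs from compound 1 elsewhere: a group of 10 heavy atoms (7 carbon, 1 nitrogen, 1 sulfur, 1 chlorine; one five-membered aromatic ring with 1 hetero atom, one six-membered aromatic ring with 1 hetero atom) in place of a group of 10 heavy atoms (7 carbon, 2 nitrogen, 1 chlorine; one five-membered aromatic ring with 2 hetero atoms, one six-membered aromatic ring of carbon only), on a sulfonyl sulfur. For the measured compounds named here, no measured step touches the sulfonyl side, so the earlier steps give no guide to direction, and the change is expected to be a number 6 percentage points lower from compound 1 to compound 4 (within the scatter). Compound 4 is therefore estimated at 25%, within a range from 5% to 55%.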

Compound 4, a percentage reported as inhibition, at one concentration (the size of the read-out at that concentration, not a potency): 58%
Compound 4: the middle estimate sits 33 percentage points below what was measured, outside the stated range (above it).
By their numbers in this assay, from the lowest: compound 2; then compounds 3 and 1 (each within the scatter of the next); then compound 4.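

The group on the sulfonyl sulfur matters in this assay: replacing 5-chloro-1H-benzimidazol-2-yl with a group of equal heavy-atom count that holds a sulfur and no hydrogen-bond donor gives a number 27 percentage points higher from compound 1 to compound 4 (beyond the scatter) on the same remaining structure. For the compounds shown here, this shows that the sulfonyl side can also shift inhibition beyond the scatter, which the earlier steps could not show. No available evidence explains the rise.

Which feature of the new group carries the step remains open. So does whether a methyl or nitrile in place of its chlorine would keep the inhibition.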